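A few compounds are considered here, and "the series" means these few. Any claim that something is new, unique, unknown or untested is made for them only; others in the source may bear on it.

Measured compounds and their values:
compound 1, `Brc1ccccc1OCC1=NCCO1`, gives 10%
compound 2, `Cc1ccccc1OCC1=NCCO1`, gives 10%
compound 3, `O=[N+]([O-])c1ccccc1OCC1=NCCO1`, gives 20%

All three were tested in a toxicity assay on the whole organism with Rattus norvegicus as the target, at a dose of 100 mg/kg by the oral route; on this read-out higher numbers stand for a stronger effect at the one dose given and lower numbers for a weaker effect. Compound 2 stands level with compound 1, the two sharing the same figure, and the step of a number 10 percentage points higher from compound 2 to compound 3 (within the scatter) keeps compound 3 within the scatter of compound 2 as well, so none of the three numbers can be set apart from the others. The change from compound 1 to compound 2, no change at the digits printed from compound 1 to compound 2 (within the scatter), and the change from compound 1 to compound 3, a number 10 percentage points higher from compound 1 to compound 3 (within the scatter), are equally small.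

The next compound, compound 4, `Cc1ccc(OCC2=NCCO2)c(C)c1`, differs from compound 2 as follows: methyl in place of hydrogen on an aromatic carbon. For the measured compounds named here, every measured step so far has exchanged one group for another on the same aromatic ring, and each stayed within the scatter; no step in this set adds a methyl in place of a hydrogen, so the nearest guide is the observation that changes on this ring have so far left the read-out where it was. On that basis the expected step of no change at the digits printed from compound 2 to compound 4 (within the scatter) is none beyond the scatter. The estimate for compound 4 in this assay is therefore 10%, with a range from 0% to 25%.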

Compound 4, a percentage reported as activity, at one dose (the size of the read-out at that dose, not a potency): 15%
Compound 4: middle estimate off by 5 percentage points, on the low side; low and high end bracket the measured number.
By their numbers in this assay, from the lowest: compounds 1, 2, 4 and 3 (each within the scatter of the next).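

In this assay, the step of a number 5 percentage points higher from compound 2 to compound 4 (within the scatter) is the only one shown that adds a group to the ring instead of exchanging one group for another, and it stays within the scatter. The earlier compounds shown here varied a single ring carbon, whereas this result reaches a second one, meta to a methyl group and para to a group of 7 heavy atoms, and a methyl in place of hydrogen there does not move the read-out beyond the scatter. Nothing available bears on why the read-out stays within the scatter at this carbon.

The compounds shown leave open whether any group at this carbon could produce a step beyond the scatter, as a single small methyl says little about an amine, a carboxylic acid or a longer chain placed there. For the compounds shown here, also open is whether the added methyl would behave the same way alongside the bromo or nitro group of the other compounds, as this one pair is the only one that carries the change.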